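Swapping the aryl amide on a shared alkyne core

The source may hold more compounds than are shown below. What is called first, only, known or untested is meant among the compounds shown, and "the series" means these compounds.

Measured compounds:
compound 1 `CC(=O)N1CCc2nc(C#Cc3ccccc3)sc2C1`: > 10000 nM
compound 2 `CC1CC1C(=O)N1CCc2nc(C#Cc3ccccc3)sc2C1`: 9.4 nM
compound 3 `N#Cc1cccc(C(=O)N2CCc3nc(C#Cc4ccccc4)sc3C2)c1`: 71 nM

In an assay on HEK293 cells for positive allosteric modulation of metabotropic glutamate receptor 5 (Homo sapiens), read by FLIPR, with a stated time of 1 h (on this read-out higher numbers stand for an effect only at larger amounts of compound and lower numbers for an effect already at smaller amounts), compound 3 gives 71 nM. Of the two numbers measured, compound 3 has the higher one; the nearest is compound 2, which gives 9.4 nM, and the gap is a 7.6-fold higher number from compound 2 to compound 3 (0.88 log units; beyond the scatter). Compound 1 reports only a limit, > 10000 nM, so the step of an at least 140-fold lower number from compound 1 to compound 3 (2.14 log units; beyond the scatter) is also only a bound.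

Compound 4 `Cc1cccc(C(=O)N2CCc3nc(C#Cc4ccccc4)sc3C2)n1` is not yet measured. It differs from compound 3 in one place: 6-methylpyridin-2-yl in place of 3-cyanophenyl on a carbonyl carbon. The measured steps that touch this position are an at least 140-fold lower number from compound 1 to compound 3 (2.14 log units; beyond the scatter) and a 7.6-fold higher number from compound 2 to compound 3 (0.88 log units; beyond the scatter); both replace a small group with a larger one, and neither exchanges one aromatic ring for another, so nothing measured here shows how an aromatic ring with one hetero atom compares with a ring of carbon only. The expected step in this assay is therefore small, a 1.1-fold higher number from compound 3 to compound 4 (0.05 log units; within the scatter), and may lie within the scatter. Compound 4 is estimated at 80 nM, with a range from 15 nM to 400 nM.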

Compound 4, half-maximal effective concentration: 160 nM
Compound 4: middle estimate off by 2.0-fold (0.30 log units), on the low side, and the stated range covers the measured number.
By their numbers in this assay, from the lowest: compound 2; then compound 3; then compound 4. At a limit, above all of these: compound 1.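

For the compounds shown here, for the first time at this position, on a carbonyl carbon bound to the ring amide nitrogen, one aromatic ring replaces another, and this gives a 2.3-fold higher number from compound 3 to compound 4 (0.35 log units; beyond the scatter) in this assay, so the choice of aromatic group does matter here. Measured against the small ring of compound 2, 6-methylpyridin-2-yl gives a 17-fold higher number from compound 2 to compound 4 (1.23 log units; beyond the scatter), which leaves compound 2 with the lowest number of the four. Compound 1 sits at a limit, so an at least 62-fold lower number from compound 1 to compound 4 (1.79 log units; beyond the scatter) is only a bound: the limit of > 10000 nM in this assay, at which 1 of the 4 values shown sits.

The change from compound 3 to compound 4 alters both the ring atoms and the group carried on the ring, so the compounds shown cannot assign the step to either one. On these data alone, how an unsubstituted phenyl group or a longer alkyl chain would behave on this carbonyl carbon also remains open.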